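A few compounds are considered here, and "the series" means these few. Any claim that something is new, unique, unknown or untested is made for them only; others in the source may bear on it.

Compound 1, `CCCc1nc(C)c2cnn(CC)c(=O)n12`: in a functional assay for inhibition, with Homo sapiens as the target (a higher number here means a weaker inhibitor, a lower number a stronger inhibitor), compound 1 gives > 48000 nM, a limit of the assay rather than a number.
Compound 2, `C=CCn1ncc2c(Br)nc(Cc3ccccc3)n2c1=O`: in this assay compound 2 gives > 48000 nM, again a limit.
Compound 3, `C=CCn1ncc2c(C)nc(Cc3ccccc3)n2c1=O`: in this assay compound 3 gives > 48000 nM, again a limit.

Compound 2 therefore stands where every measured compound stands: the limit of > 48000 nM in this assay, at which 3 of the 3 values shown sit. Among the compounds with values here, the one step between measured compounds that differ in a single group, a step that the two limits leave unreadable from compound 2 to compound 3, cannot be read, since both ends of it are limits.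

The new compound 4 is `C=CCn1ncc2c(Br)nc(CCC)n2c1=O`. It differs from compound 2 in one way: ethyl in place of phenyl on a saturated chain carbon bound to an aromatic carbon. Within the data shown here, no measured step concerns this change; the single measured step concerns another group and is unreadable in any case. Nothing in the data points to a reading inside the range of the assay, because of the limit of > 48000 nM in this assay, at which 3 of the 3 values shown sit. Compound 4 is therefore expected to show no readable step, a step that the limit leaves unreadable from compound 2 to compound 4, and most likely to return a limit again. The estimate for compound 4 is 100000 nM, expected to lie between 48000 nM and 300000 nM.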

Compound 4, half-maximal inhibitory concentration: > 48000 nM
Compound 4: only a limit was reported; the forecaster's own chance of this, stated with the estimate: 85%; the middle value is on the limit's open side.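

Within the data shown here, compound 2 and compound 4 both return only a limit in this assay, so the change from benzyl to propyl gives no step that can be read: the limit of > 48000 nM in this assay, at which 4 of the 4 values shown sit.
The compounds shown leave open which change, if any, would bring a reading inside the range of this assay for the shared core.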